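Hydroxy to Methoxy: What Compound 4 Should Give

The source may hold more compounds than are shown below. What is called first, only, known or untested is meant among the compounds shown, and "the series" means these compounds.

Compound 1, `O=C(Nc1cccc(-n2cc(-c3ccncc3)c(-c3cc(O)cc(Cl)c3)n2)c1)Nc1ccc(Cl)c(C(F)(F)F)c1`, gives 9.31% in a functional assay on CCRF-CEM cells (Homo sapiens) for inhibition, read by sulforhodamine B assay, with a stated time of 48 h, tested at 10 uM; a lower number here means a stronger effect, a higher number a weaker effect of the compound at the concentration tested.
Compound 2, `COc1cc(Cl)cc(-c2nn(-c3cccc(NC(=O)Nc4ccc(Cl)c(C(F)(F)F)c4)c3)cc2-c2ccncc2)c1`, gives 1.88% in this assay.
Compound 3, `O=C(Nc1cccc(-n2cc(-c3ccncc3)c(-c3cc(O)cc(Cl)c3)n2)c1)c1cc(C(F)(F)F)cc(C(F)(F)F)c1`, gives 26.9% in this assay.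

Compound 2 differs from compound 1 in one place only, (methyl in place of hydrogen on an oxygen on an aromatic ring), and the step that goes with it is a number 7.4 percentage points lower from compound 1 to compound 2 (within the scatter), so the two numbers are not distinguishable by this read-out. Compound 3 has the highest number of the three; its gap to compound 1 and its gap to compound 2 both lie beyond the scatter, so its effect at the tested concentration is weaker than that of either. The difference between the core of compound 1 and the core of compound 3 is not broken down here.

Compound 4, `COc1cc(Cl)cc(-c2nn(-c3cccc(NC(=O)c4cc(C(F)(F)F)cc(C(F)(F)F)c4)c3)cc2-c2ccncc2)c1`, has not yet been tested in this assay. It stands to compound 3 as compound 2 stands to compound 1: the change is methyl in place of hydrogen on an oxygen on an aromatic ring, the same change at the same place. For the measured compounds named here, the only guide to its size is the earlier step, a number 7.4 percentage points lower from compound 1 to compound 2 (within the scatter), which stayed within the scatter. On that basis the step from compound 3 to compound 4 is expected to be small as well, a number 5.9 percentage points lower from compound 3 to compound 4 (within the scatter), because the same change gave a number 7.4 percentage points lower from compound 1 to compound 2 (within the scatter). Compound 4 is therefore estimated to give 21% in this assay, with a likely range from 8% to 36%.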

Compound 4, a percentage reported as activity, at one concentration (the size of the read-out at that concentration, not a potency): 57.1%
The estimate for compound 4 lay 36.1 percentage points below the measured number; the whole stated range lies below it.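

Hydroxy to methoxy did not carry over from one core to the other: in this assay, the change on the core of compound 3 gave a number 30.2 percentage points higher from compound 3 to compound 4 (beyond the scatter), a large step, while the same change on the core of compound 1 gave a number 7.4 percentage points lower from compound 1 to compound 2 (within the scatter). The two steps differ, which shows that in this series the outcome of the change depends on the core that carries it: the same change on two cores in this assay, a number 7.4 percentage points lower (within the scatter) from compound 1 to compound 2 and a number 30.2 percentage points higher (beyond the scatter) from compound 3 to compound 4, 37.6 percentage points apart, beyond the scatter of two such steps

For the compounds shown here, this rests on one pair of steps on two cores, and it shows only that a step seen on one of these cores could not be taken over to the other. It does not show which part of the cores accounts for the gap or why the change weakens the effect on one core alone, and it gives no rule for any further core.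

The compounds shown carry only hydroxy or methoxy at this place, so it stays open whether a longer chain on the oxygen, such as ethoxy, would follow the step seen on the core of compound 1 or the one seen on the core of compound 3. The same question stands for an amine in place of the hydroxy on either core.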